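Amide nitrogen substituent exchange on the shared core

The source may hold more compounds than are shown below. What is called first, only, known or untested is meant among the compounds shown, and "the series" means these compounds.

Compound 3 `O=C(NCc1cccnc1)c1c(O)c2cccnc2n(-c2ccccc2)c1=O` gives 25.5% in a functional assay on the whole organism for inhibition, with Rattus norvegicus as the target, read by paw edema, at a dose of 100 mg/kg by the oral route (a lower number here means less inhibition, a higher number more inhibition at the dose given (going by the name of the read-out)), the highest of the three numbers recorded so far. Compound 1 `CCOC(=O)c1c(O)c2cccnc2n(-c2ccccc2)c1=O` gives 23.5%, a gap from compound 3 that lies within the scatter, while compound 2 `Cc1ccc(NC(=O)c2c(O)c3cccnc3n(-c3ccccc3)c2=O)cc1` gives -3.5%, well below both. Compound 4 `Cc1cnccc1NC(=O)c1c(O)c2cccnc2n(-c2ccccc2)c1=O` differs from compound 3 in one place: 3-methylpyridin-4-yl in place of (pyridin-3-yl)methyl on an amide-type nitrogen. Going by the values given here, two measured steps bear on this change. The step of a number 29 percentage points higher from compound 2 to compound 3 (beyond the scatter) concerns the same amide-type nitrogen, and compound 4 resembles compound 2 in placing a six-membered aromatic ring on that nitrogen without the (pyridin-3-yl)methyl group. The step of a number 27 percentage points lower from compound 1 to compound 2 (beyond the scatter) shows the same low number for compound 2 from the other side, whereas a number 2 percentage points higher from compound 1 to compound 3 (within the scatter) stays within the scatter. A drop beyond the scatter is therefore expected for compound 4, roughly reversing the step from compound 2, as a number 19.5 percentage points lower from compound 3 to compound 4 (beyond the scatter). Compound 4 is estimated at 6%, with a range from -15% to 28%.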

Compound 4, a percentage reported as inhibition, in the whole organism at one dose (the size of the read-out at that dose, not a potency): 26.9%
Estimate against measurement, compound 4: 20.9 percentage points below; measured number inside the range.
By their numbers in this assay, from the lowest: compound 2; then compounds 1, 3 and 4 (each within the scatter of the next).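

In this assay, a six-membered aromatic ring on the amide-type nitrogen does not by itself bring the low number of compound 2, since 3-methylpyridin-4-yl in place of 4-methylphenyl gives a number 30.4 percentage points higher from compound 2 to compound 4 (beyond the scatter) in this series. Replacing (pyridin-3-yl)methyl with 3-methylpyridin-4-yl gives a number 1.4 percentage points higher from compound 3 to compound 4 (within the scatter) and replacing ethoxy on the carbonyl carbon with (3-methylpyridin-4-yl)amino gives a number 3.4 percentage points higher from compound 1 to compound 4 (within the scatter), so compound 2 alone stands apart and compounds 1, 3 and 4 cannot be ordered. Nothing on hand accounts for the gap between compound 2 and compound 4.

Going by these compounds, whether a pyridin-4-yl group without the methyl or a plain phenyl group on that nitrogen would fall with compound 2 or with compound 4 remains open. The same holds for a carboxylic acid in place of the ethyl ester of compound 1.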